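Swapping the Aryl Group on a Piperazine Sulfonamide

The compounds below may be only part of what the source reports. "The series", "measured", "known", "first", "only" and "open" are said of these compounds alone.

This small set of compounds shares a bicyclic ketone core carrying a sulfonyl group, and the compounds differ in the amine that the sulfonyl group attaches to and in the aromatic ring hung on that amine. Compound 1 `CC1CN(S(=O)(=O)C[C@]23CC[C@H](CC2=O)C3(C)C)CCN1c1ccc(C(F)(F)F)cn1` is the only one of the three measured compounds to give a number in a functional assay on CHO-K1 cells for antagonist activity at C-X-C chemokine receptor type 3 (Homo sapiens), read by FLIPR and calcium flux (a higher number here means a weaker inhibitor, a lower number a stronger inhibitor), where compound 1 reaches 316 nM. Compound 3 `CN(CCN(C)S(=O)(=O)C[C@]12CC[C@H](CC1=O)C2(C)C)c1ccc(C(F)(F)F)cn1`, with an open-chain amine in place of a ring, reaches only the limit of the assay, reported for compound 3 as > 31600 nM. Compound 2 `Cc1ccc(N2CCN(S(=O)(=O)C[C@]34CC[C@H](CC3=O)C4(C)C)CC2)nc1` also stands at the limit, given for compound 2 as > 31600 nM. So compound 2 sits among the inactive members of the set, with two of the three values at that limit (the limit of > 31600 nM in this assay, at which 2 of the 3 values shown sit).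

Compound 4 `CC1(C)[C@@H]2CC[C@@]1(CS(=O)(=O)N1CCN(c3ccc(C(F)(F)F)nn3)CC1)C(=O)C2` is not yet measured. It differs from compound 2 by 6-(trifluoromethyl)pyridazin-3-yl in place of 5-methylpyridin-2-yl on an amine nitrogen in a ring. Among the measured compounds shown here, no measured pair isolates this exact change, so the expectation rests on the observation that compound 1, the only active compound, carries a trifluoromethyl on its aromatic ring, while compound 2 carries a methyl. The step from compound 2 to compound 4 is therefore expected to move toward stronger inhibition, an estimated at least 12-fold lower number from compound 2 to compound 4 (1.10 log units; beyond the scatter), though a result that again reaches only the limit cannot be excluded. Compound 4 is estimated at 2500 nM in this assay, within a range from 250 nM to 31600 nM.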

Compound 4, half-maximal inhibitory concentration: 5010 nM
Compound 4: middle estimate off by 2.0-fold (0.30 log units), on the low side, and the stated range covers the measured number.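

In this assay, 6-(trifluoromethyl)pyridazin-3-yl in place of 5-methylpyridin-2-yl on the amine nitrogen in the ring gives an at least 6.3-fold lower number from compound 2 to compound 4 (0.79 log units; beyond the scatter). Among the compounds shown here, this is the first direct evidence that the aromatic group at this position can decide whether a compound gives a measurable number, with the rest of the molecule unchanged. The step is only a lower bound, as the value for compound 2 is a limit of the assay: the limit of > 31600 nM in this assay, at which 2 of the 4 values shown sit.

The change swaps the methyl for a trifluoromethyl and the pyridine for a pyridazine at once, so the compounds shown cannot say which of the two matters, and compound 1 differs from compound 4 in more than one place. Going by these compounds, how a nitrile or a chlorine would behave on the same aromatic ring also remains open.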